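The source may report more compounds than this note shows. Statements on the series, on what has been measured and on what is new or still open speak of the compounds shown alone.

Working notes on the triazole series.

Compound 1 `CCSc1nnc(Cc2ccccc2Oc2ccccc2)[nH]1` gives 142% in a functional assay on the whole organism (strain NMRI) with Mus musculus as the target, with a stated time of 60 min, at a dose of 10 mg/kg by the intraperitoneal route; on this read-out lower numbers stand for a weaker effect and higher numbers for a stronger effect at the one dose given. Compound 2 `CCCSc1nnc(Cc2ccccc2Oc2ccccc2)[nH]1` gives 139% in this assay, and the step of a number 3 percentage points lower from compound 1 to compound 2 (within the scatter) is the change (methyl in place of hydrogen on a saturated chain carbon, two bonds along the chain from a sulfur). Compound 3 `CSc1nnc(Cc2ccc(Cl)cc2Oc2ccccc2Cl)[nH]1` gives 132% in this assay; the difference between the core of compound 3 and the core of compound 1 is not broken down here, and the three values lie within the scatter of each other.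

Compound 4 `CCSc1nnc(Cc2ccc(Cl)cc2Oc2ccccc2Cl)[nH]1` is not yet measured. It differs from compound 3 by methyl in place of hydrogen on a saturated chain carbon bound to a sulfur. Within the data shown here, this is the same kind of change as the one from compound 1 to compound 2, not the same: there the new methyl sits on a saturated chain carbon two bonds along the chain from a sulfur, here on a saturated chain carbon bound to a sulfur. For compound 4 the step of a number 3 percentage points higher from compound 3 to compound 4 (within the scatter) is expected, comparable in size to the earlier step, because a number 3 percentage points lower from compound 1 to compound 2 (within the scatter) lies within the scatter. Compound 4 is therefore estimated at 135% in this assay, most likely between 115% and 155%.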

Compound 4, a percentage reported as activity, at one dose (the size of the read-out at that dose, not a potency): 140%
Beside the measured number, compound 4's estimate is 5 percentage points below it; measured number inside the range.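

In this assay, the step on the core of compound 3 is a number 8 percentage points higher from compound 3 to compound 4 (within the scatter), so methylsulfanyl to ethylsulfanyl leaves the read-out within the scatter on this core. Set beside the earlier step, the added methyl shows no difference between the two cores that can be told apart: the same change on two cores in this assay, a number 3 percentage points lower (within the scatter) from compound 1 to compound 2 and a number 8 percentage points higher (within the scatter) from compound 3 to compound 4, 11 percentage points apart, within the scatter of two such steps. This does not show that the change carries over to every core in the series: the two steps differ in place, with the methyl on a saturated chain carbon bound to a sulfur in one and on a saturated chain carbon two bonds along the chain from a sulfur in the other, and each step rests on a single dose.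

The compounds shown leave open whether a longer chain on the sulfur, such as butyl, or an amine or a carboxylic acid at the end of that chain, would move the read-out beyond the scatter. They also leave open what each chlorine on the core of compound 3 contributes on its own.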